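A Nitro Group Enters Where Chloro Once Helped

The source may hold more compounds than are shown below. What is called first, only, known or untested is meant among the compounds shown, and "the series" means these compounds.

Compound 3 `COc1cc2ccc(=O)oc2cc1OC(=O)c1c(C)noc1-c1ccccc1` gives 22700 nM in a functional assay on HCT-116 cells (Homo sapiens) for inhibition, read by MTT assay, with a stated time of 48 h (a lower number here means a stronger inhibitor, a higher number a weaker inhibitor), the higher of the two plain numbers shown, with compound 1 `COc1cc2ccc(=O)oc2cc1OC(=O)c1c(C)noc1-c1ccc(Cl)cc1` at 10900 nM as its nearest neighbour. Compound 2 `COc1cc2ccc(=O)oc2cc1OC(=O)c1c(C)noc1-c1ccccc1F` reaches only the limit of this assay, > 25000 nM. Compound 4 `COc1cc2ccc(=O)oc2cc1OC(=O)c1c(C)noc1-c1ccc([N+](=O)[O-])cc1` carries nitro in place of hydrogen on an aromatic carbon, para to a large group. The step that bears on it most is the change of chloro to hydrogen on an aromatic carbon, a 2.1-fold higher number from compound 1 to compound 3 (0.32 log units; beyond the scatter), while an at least 1.1-fold lower number from compound 2 to compound 3 (0.04 log units; that floor lies within the scatter). Since a group on an aromatic carbon of that ring went with a lower number in compound 1, a modest lowering is expected for compound 4, a 1.9-fold lower number from compound 3 to compound 4 (0.28 log units; within the scatter). For compound 4 the expected value in this assay is 12000 nM, within 4000 nM to 30000 nM.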

Compound 4, half-maximal inhibitory concentration: 9210 nM
Compound 4: middle estimate off by 1.3-fold (0.11 log units), on the high side; the range from low to high includes it.
By their numbers in this assay, from the lowest: compounds 4 and 1 (each within the scatter of the next); then compound 3. At a limit, above all of these: compound 2.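

At the position para to a large group, a second group now goes with a lower number than hydrogen: nitro in compound 4 (a 2.5-fold lower number from compound 3 to compound 4 (0.39 log units; beyond the scatter)) joins chloro in compound 1. Nitro and chloro cannot be told apart here (a 1.2-fold lower number from compound 1 to compound 4 (0.07 log units; within the scatter)). The 4-nitrophenyl group also separates from the 2-fluorophenyl group (an at least 2.7-fold lower number from compound 2 to compound 4 (0.43 log units; beyond the scatter)), though that step is only a floor, as compound 2 holds a limit of the assay rather than a number.

Going by these compounds, whether an amine or a carboxylic acid at this position would also lower the number stays open.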